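The compounds below may be only part of what the source reports. "The series", "measured", "known", "first", "only" and "open" are said of these compounds alone.

Working notes on the series. Compound 1 `CCOc1ccc(-c2ccc3ncn(-c4cc(OC)c(OC)c(OC)c4)c3c2)cc1` is the reference point. In a functional assay on SGC-7901 cells (Homo sapiens) for antiproliferative activity, read by MTT assay, with a stated time of 72 h (on this read-out higher numbers stand for weaker inhibition and lower numbers for stronger inhibition), compound 1 gives 2970 nM, the highest of the two numbers obtained so far; the nearest is compound 2 `COc1cc(-n2cnc3ccc(-c4ccc(C(C)=O)cc4)cc32)cc(OC)c1OC`, which in this assay gives 450 nM. Within the data shown here, the step of a 6.6-fold lower number from compound 1 to compound 2 (0.82 log units; beyond the scatter) is the only measured change at this place on the shared core. Compound 3 `COc1cc(-n2cnc3ccc(-c4ccc(Cl)cc4Cl)cc32)cc(OC)c1OC` in this assay returns only a limit, > 10000 nM. That value sits at the limit of > 10000 nM in this assay, at which 1 of the 3 values shown sits. The steps of an at least 3.3-fold higher number from compound 1 to compound 3 (0.52 log units; beyond the scatter) and an at least 22-fold higher number from compound 2 to compound 3 (1.34 log units; beyond the scatter) exchange the whole 4-ethoxyphenyl or 4-acetylphenyl for 2,4-dichlorophenyl, so they speak to the ring as a unit rather than to the single substituent.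

Compound 4 `COc1cc(-n2cnc3ccc(-c4ccc(O)cc4)cc32)cc(OC)c1OC` differs from compound 1 by hydrogen in place of ethyl on an oxygen on an aromatic ring. Among the measured compounds shown here, the one measured step at this position, a 6.6-fold lower number from compound 1 to compound 2 (0.82 log units; beyond the scatter), moved the number modestly, but acetyl in place of ethoxy is not hydrogen in place of ethyl, so no direction follows from it. The change leaves the rest of compound 1 untouched and may well stay within the scatter, or shift the number modestly either way. On that basis compound 4 is expected to give 3000 nM in this assay, with a range of 900 nM to 10000 nM. The estimate for compound 4 amounts to a 1.0-fold higher number from compound 1 to compound 4 (0.00 log units; within the scatter), expected to stay near the scatter.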

Compound 4, half-maximal inhibitory concentration: > 10000 nM
Compound 4 gave a limit, no number; the forecaster's own chance of this, stated with the estimate: 15%; middle value at least 3.3-fold (0.52 log units) away from the limit.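

Hydrogen in place of ethyl on this oxygen is not a silent change in this assay: the step of an at least 3.3-fold higher number from compound 1 to compound 4 (0.52 log units; beyond the scatter) shows that the ethyl itself counts at this place, whereas the earlier steps exchanged either the whole ethoxy or the whole ring. The step of an at least 22-fold higher number from compound 2 to compound 4 (1.34 log units; beyond the scatter) adds that hydroxy and acetyl, both single groups on the same aromatic carbon of the 4-substituted phenyl, lie far apart on this read-out, so a single substituent here can decide between a measured number and no number at all. The value of compound 4 is a limit of the assay and not a number, and it is the second such value in the series: the limit of > 10000 nM in this assay, at which 2 of the 4 values shown sit.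

On these data alone, the step between the two limits cannot be read, so the order of compound 3 and compound 4 stays open, and both readable steps give only a lower bound on their size. The compounds shown also leave open whether the oxygen needs any alkyl group at all or this particular one, which methoxy, a longer alkoxy chain, an amine or a carboxylic acid on the same aromatic carbon would begin to settle.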